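The source may hold more compounds than are shown below. What is called first, only, known or untested is meant among the compounds shown, and "the series" means these compounds.

Of the compounds shown here, three built on one shared core have been tested in a functional assay on T47D cells (Homo sapiens) for cytotoxicity, read by CCK-8 assay, with a stated time of 4 days; a lower number here means a stronger inhibitor, a higher number a weaker inhibitor. Compound 1 `Oc1ccc(-c2cc(-c3cccc(O)c3)nc(-c3ccccc3O)c2)cc1` gives 4810 nM, compound 2 `Oc1ccc(-c2cc(-c3cccc(O)c3)nc(-c3cccc(O)c3)c2)cc1` gives 2230 nM, and compound 3 `Oc1ccc(-c2cc(-c3ccccc3O)cc(-c3ccc(O)cc3)n2)cc1` gives 5350 nM. Compound 2 thus has the lowest number of the three, with compound 1 nearest and compound 3 furthest, and both of those gaps lie beyond the scatter.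

Compound 4 `Oc1cccc(-c2cc(-c3cccc(O)c3)nc(-c3cccc(O)c3)c2)c1` differs from compound 2 in one place: 3-hydroxyphenyl in place of 4-hydroxyphenyl on an aromatic carbon. Among the compounds with values here, the only measured step that bears on this, a 2.2-fold lower number from compound 1 to compound 2 (0.33 log units; beyond the scatter), was a modest move to a lower number, and it too brought in a 3-hydroxyphenyl; yet it replaced a 2-hydroxyphenyl rather than a 4-hydroxyphenyl, so it is only a loose guide. Within the data shown here, no measured pair exchanges a 4-hydroxyphenyl for a 3-hydroxyphenyl. The expected step, a 1.2-fold lower number from compound 2 to compound 4 (0.09 log units; within the scatter), is therefore small, a little lower if anything, and most likely within the scatter. Compound 4 is expected to give about 1800 nM in this assay, within a range from 700 nM to 4500 nM.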

Compound 4, half-maximal inhibitory concentration: 2050 nM
For compound 4 the middle estimate is 1.1-fold (0.06 log units) below the measured one; low and high end bracket the measured number.
By their numbers in this assay, from the lowest: compounds 4 and 2 (each within the scatter of the next); then compounds 1 and 3 (each within the scatter of the next).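

In this assay, the new result is a 1.1-fold lower number from compound 2 to compound 4 (0.04 log units; within the scatter). On the aromatic carbon opposite the ring nitrogen, a 3-hydroxyphenyl can therefore stand in for a 4-hydroxyphenyl with no change that can be told from the scatter, so moving the hydroxyl group around this ring makes no clear difference here, unlike the earlier step away from a 2-hydroxyphenyl, which went beyond the scatter. No measurement at hand explains why this change leaves the number so close.

The compounds shown leave open whether this position depends on having a hydroxyl group on this ring at all. A plain phenyl, or a ring carrying an amine or a carboxylic acid instead, would test how much change the position accepts before the number moves.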